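The compounds below may be only part of what the source reports. "The series", "measured", "known", "first", "only" and "open" are said of these compounds alone.

For the measured compounds named here, compound 2 `COc1ccc(/C=C/c2cc(OC)cc(OC)c2/C=C/C(=O)c2ccc(N)cc2)cc1` gives 3.8 ug/mL in a functional assay on A549 cells (Homo sapiens) for antiproliferative activity, read by MTT assay, with a stated time of 48 h (on this read-out lower numbers stand for stronger inhibition and higher numbers for weaker inhibition), the lower of the two numbers measured so far. Compound 1 `CCCCCCCCCCCCOc1ccc(C(=O)/C=C/c2c(/C=C/c3ccc(OC)cc3)cc(OC)cc2OC)cc1` gives 7.9 ug/mL in this assay, and the gap between these two values lies beyond the usual scatter. Compound 3 `COc1ccc(/C=C/c2cc(OC)cc(OC)c2/C=C/C(=O)c2ccc(C)c(C)c2)cc1` differs from compound 2 in a single place: 3,4-dimethylphenyl in place of 4-aminophenyl on a carbonyl carbon. Going by the values given here, no measured pair shows this change, so its effect is unknown; only a modest step is expected, a 1.4-fold higher number from compound 2 to compound 3 (0.16 log units; within the scatter), toward a somewhat higher number. Compound 3 is therefore estimated at 5.5 ug/mL in this assay, with a range from 2 ug/mL to 15 ug/mL.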

Compound 3, half-maximal inhibitory concentration: 0.1 ug/mL
For compound 3 the middle estimate is 55-fold (1.74 log units) above the measured one; measured number below the stated range.
By their numbers in this assay, from the lowest: compound 3; then compound 2; then compound 1.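

For the compounds shown here, this is the first sign that the group on the carbonyl carbon can strongly shift the result: in this assay, 3,4-dimethylphenyl in place of 4-aminophenyl gives a 38-fold lower number from compound 2 to compound 3 (1.58 log units; beyond the scatter), a large step from one change in one place. Nothing measured here explains why the number falls so far. The compounds shown leave open whether the step comes from losing the amino group, gaining the two methyl groups, or both. A plain phenyl or a phenyl with a single methyl group could help separate these possibilities.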